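This account rests on a few compounds, and the source may have more. Where it says the series, first, only, none or still open, it means among the compounds named here.

Measured compounds:
compound 1 `C=CCc1cc(-c2ccc(C(F)(F)F)cc2)ccc1O` — 76000 nM
compound 2 `C=CCc1cc(-c2ccc(C(F)(F)F)cc2)ccc1OC` — > 100000 nM
compound 3 `C=CCc1ccc(OCC(=O)OCC)c(-c2ccc(OCC(=O)OCC)c(CC=C)c2)c1` — > 91300 nM

In a functional assay on A549 cells (Homo sapiens) for antiproliferative activity, read by MTT assay, with a stated time of 24 h (on this read-out higher numbers stand for weaker inhibition and lower numbers for stronger inhibition), compound 1 gives 76000 nM. Compound 2 gives > 100000 nM, which is a limit of the assay and not a number. Compound 3 gives > 91300 nM, also a limit of the assay and not a number, so compound 3 stands at the weak end of what this assay can resolve, alongside (the limit of > 91300 nM in this assay, at which 1 of the 3 values shown sits). Going by the values given here, the one step between measured compounds that differ in a single place is an at least 1.3-fold higher number from compound 1 to compound 2 (0.11 log units; that floor lies within the scatter), a methyl in place of hydrogen on an oxygen on an aromatic ring; it ends at the limit of > 100000 nM in this assay, at which 1 of the 3 values shown sits, and stays within the scatter.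

Compound 4 `C=CCc1cc(C=O)c(OCC(=O)OCC)c(-c2ccc(OCC(=O)OCC)c(CC=C)c2)c1` follows from compound 3 by the change (formyl in place of hydrogen on an aromatic carbon). Among the compounds with values here, no measured step touches a change of this kind on an aromatic carbon, and the one step available lies within the scatter, so no shift beyond the scatter is expected in this assay from compound 3 to compound 4. The expected step is a step that the limit leaves unreadable from compound 3 to compound 4. Compound 4 is therefore estimated at 100000 nM, with a range from 30000 nM to 300000 nM, and a limit rather than a number is quite likely to be reported.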

Compound 4, half-maximal inhibitory concentration: > 85800 nM
Compound 4: no number, only a limit (the forecaster's own chance of this, stated with the estimate: 60%); the middle value does not contradict the limit.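

In this assay, compound 3 and compound 4 are each reported only as a limit of the assay and not as a number, so the step between them, formyl in place of hydrogen on an aromatic carbon, cannot be read. The compounds shown leave open whether this change shifts antiproliferative activity in either direction.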